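Thiophen-3-yl in place of 4-methoxyphenyl: working notes

This account rests on a few compounds, and the source may have more. Where it says the series, first, only, none or still open, it means among the compounds named here.

Among the measured compounds shown here, in a functional assay on DU-145 cells (Homo sapiens) for inhibition, read by MTT assay, with a stated time of 48 h (a lower number here means a stronger inhibitor, a higher number a weaker inhibitor), compound 1 (`COc1ccc(-c2nc3ccccn3c2Sc2ccccc2)cc1`) gives 76800 nM and stands as the higher of the two numbers so far, which makes it the weaker inhibitor of the pair. Compound 2 (`CS(=O)(=O)c1ccc(-c2nc3ccccn3c2Sc2cccc3ccccc23)cc1`) gives 20800 nM and lies lower, beyond the scatter. These two compounds differ in more than one place, so their gap cannot be assigned to any single group.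

Compound 3 (`c1ccc(Sc2c(-c3ccsc3)nc3ccccn23)cc1`) carries thiophen-3-yl in place of 4-methoxyphenyl on an aromatic carbon. For the measured compounds named here, no measured pair isolates this exchange, so the expectation rests on compound 1 (76800 nM). The expected step in this assay is small, with no change beyond the scatter (a 1.3-fold lower number from compound 1 to compound 3 (0.11 log units; within the scatter)). The estimate for compound 3 is 60000 nM (expected range 22000 nM to 150000 nM).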

Compound 3, half-maximal inhibitory concentration: 85900 nM
The estimate for compound 3 lay 1.4-fold (0.16 log units) below the measured number; low and high end bracket the measured number.
By their numbers in this assay, from the lowest: compound 2; then compounds 1 and 3 (each within the scatter of the next).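

In this assay, among the compounds shown here, the exchange of 4-methoxyphenyl for thiophen-3-yl gives a 1.1-fold higher number from compound 1 to compound 3 (0.05 log units; within the scatter) and supplies the first step that isolates a single change. At this aromatic carbon of the five-membered aromatic ring with 2 nitrogen, going from 8 heavy atoms to 5, and from a six-membered aromatic ring of carbon only to a five-membered aromatic ring with 1 hetero atom, leaves the number within the scatter. No supporting data on hand account for this flat step.

As far as these compounds go, whether a non-aromatic group on this carbon, such as an amine, a carboxylic acid or a longer alkyl chain, would shift the number beyond the scatter remains open. Also open, from the compounds shown here alone, is whether the exchange would behave alike with a group other than phenylsulfanyl on the neighbouring ring atom.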